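This account rests on a few compounds, and the source may have more. Where it says the series, first, only, none or still open, it means among the compounds named here.

Measured so far:
Compound 1 `CCN(CC)CCNC(=O)c1cc(C(CC)(CC)c2ccc(C#CC(O)(CC)CC)c(C)c2)cn1CC` in an assay on cells for agonist activity at vitamin D3 receptor (Homo sapiens), read by microscopy; a lower number here means that less compound is needed, a higher number that more compound is needed for the effect: compound 1 gives 6.98 nM.
Compound 2 `CCn1cc(C(CC)(CC)c2ccc(C#CC(O)(CC)CC)c(C)c2)cc1C(=O)NCC(=O)O`: compound 2 gives 54.3 nM.
Compound 3 `CCn1cc(C(CC)(CC)c2ccc(C#CC(O)(CC)CC)c(C)c2)cc1C(=O)NCCC(=O)O`: compound 3 gives only a limit, > 50 nM.

Compound 3 therefore has no exact number; it sits at the limit of > 50 nM in this assay, at which 1 of the 3 values shown sits. Compound 4 `CCn1cc(C(CC)(CC)c2ccc(C#CC(O)(CC)CC)c(C)c2)cc1C(=O)N[C@H](C(=O)O)C(C)C` differs from it by 1-carboxy-2-methylpropyl in place of 2-carboxyethyl on an amide-type nitrogen. Among the measured compounds shown here, two measured steps bear on this: an at least 7.1-fold higher number from compound 1 to compound 3 (0.85 log units; beyond the scatter) and a step that the limit leaves unreadable from compound 2 to compound 3. The carboxy group of compound 4 sits on the carbon bound to the amide-type nitrogen, as in compound 2, where a 7.8-fold higher number from compound 1 to compound 2 (0.89 log units; beyond the scatter) was seen. Compound 4 is thus expected to land near the weaker acids, at an estimated 60 nM with a range of 20 nM to 200 nM. The expected step is a step that the limit leaves unreadable from compound 3 to compound 4, possibly again only a limit.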

Compound 4, half-maximal effective concentration: 12.7 nM
Compound 4: middle estimate off by 4.7-fold (0.67 log units), on the high side; measured number outside the range, below it.
By their numbers in this assay, from the lowest: compounds 1 and 4 (each within the scatter of the next); then compound 2.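

In this assay, isopropyl in place of hydrogen on the saturated chain carbon gives a 4.3-fold lower number from compound 2 to compound 4 (0.63 log units; beyond the scatter), so the group on that carbon matters even with the carboxy group held in place. Compound 3 gives only a limit of the assay, not a number: the limit of > 50 nM in this assay, at which 1 of the 4 values shown sits. Against that limit, the new group gives an at least 3.9-fold lower number from compound 3 to compound 4 (0.59 log units; beyond the scatter), while replacing the amine chain gives a 1.8-fold higher number from compound 1 to compound 4 (0.26 log units; within the scatter), so this acid and the amine of compound 1 cannot be told apart.

From the compounds shown here alone, whether methyl or benzyl on that carbon would serve like isopropyl stays open. So does the effect of the opposite arrangement at the defined stereocentre of compound 4.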